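Permeability notes: benzyl swap at the core of compound 3

The source may report more compounds than this note shows. Statements on the series, on what has been measured and on what is new or still open speak of the compounds shown alone.

Measured compounds in an ADME assay for permeability, using PAMPA, with a stated time of 30 min, at pH 7.4; a lower number here means that the compound crosses the layer more slowly, a higher number that the compound crosses the layer faster:
compound 1 `COc1cccc(Oc2ccc3c(NCCCNCc4cccc(OC)c4O)ccnc3c2)c1` gives 317 10^-6 cm/s
compound 2 `COc1ccc(F)cc1CNCCCNc1ccnc2cc(Cc3ccc(F)cc3Cl)ccc12` gives 23 10^-6 cm/s
compound 3 `COc1cccc(CNCCCNc2ccnc3cc(Cc4cccc(C(F)(F)F)c4)ccc23)c1O` gives 23 10^-6 cm/s

Compound 3 sits at the low end of the measured set: in this assay compound 3 is level with compound 2 at the digits shown, within the scatter, while compound 1 stands well above it, the difference from compound 1 to compound 3 being a 14-fold lower number from compound 1 to compound 3 (1.14 log units; beyond the scatter).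

Compound 4 `COc1cccc(CNCCCNc2ccnc3cc(Cc4ccc(F)cc4Cl)ccc23)c1O` is not yet measured. It differs from compound 3 in one place: 2-chloro-4-fluorophenyl in place of 3-(trifluoromethyl)phenyl on a saturated chain carbon bound to an aromatic carbon. Among the measured compounds shown here, no measured step covers this exact exchange. For the measured compounds named here, the one measured step, a 14-fold lower number from compound 1 to compound 3 (1.14 log units; beyond the scatter), concerns a different change and does not bear on it directly. The closest guide is compound 2, which carries the same 2-chloro-4-fluorobenzyl that enters compound 4 and whose value in this assay matches that of compound 3 within the scatter. On that basis no step beyond the scatter is expected, and the estimated step is no change at the digits printed from compound 3 to compound 4 (within the scatter).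

Compound 4 is therefore expected to give about 23 10^-6 cm/s in this assay, with a likely range from 10 10^-6 cm/s to 55 10^-6 cm/s.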

Compound 4, apparent permeability: 23 10^-6 cm/s
Compound 4: middle estimate and measured number agree at the digits printed; the measured number falls inside the stated range.
By their numbers in this assay, from the lowest: compounds 2, 3 and 4 (each within the scatter of the next); then compound 1.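

In this assay, 2-chloro-4-fluorophenyl in place of 3-(trifluoromethyl)phenyl on a saturated chain carbon bound to an aromatic carbon gives no change at the digits printed from compound 3 to compound 4 (within the scatter) as the step, and 2-hydroxy-3-methoxyphenyl in place of 5-fluoro-2-methoxyphenyl on a saturated chain carbon bound to an amine nitrogen gives no change at the digits printed from compound 2 to compound 4 (within the scatter) as the step. The second benzyl group on the aromatic carbon shows a large step as well, with 2-chloro-4-fluorobenzyl in place of 3-methoxyphenoxy giving a 14-fold lower number from compound 1 to compound 4 (1.14 log units; beyond the scatter) as the change, so the large step does not rest on 3-(trifluoromethyl)benzyl alone. No supporting data bear on the reason for these results.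

Among the compounds shown here, compound 1 is the only phenoxy compound, so the high end of the series rests on a single structure. As far as these compounds go, whether an amine or a carboxylic acid on the benzyl ring, or a longer chain, would shift the number remains open.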